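The compounds below may be only part of what the source reports. "The series", "measured", "known", "first", "only" and "open" are said of these compounds alone.

Compound 1 `COc1cc(/C=C2\CNC/C(=C\c3cc(OC)c(OC)c(OC)c3)C2=O)cc(OC)c1OC`: 4000 nM
Compound 2 `COc1ccc(/C=C2\CN(C)C/C(=C\c3ccc(OC)c(OC)c3)C2=O)cc1OC`: 6600 nM

In a functional assay on NCI-H1975 cells (Homo sapiens) for cytotoxicity, read by MTT assay, with a stated time of 72 h (a lower number here means a stronger inhibitor, a higher number a weaker inhibitor), compound 1 at 4000 nM and compound 2 at 6600 nM lie within the usual scatter of each other, so compound 1 does not stand apart on these numbers. Compound 3 `COc1cc(/C=C2\CN(C(=O)c3ccccc3F)C/C(=C\c3cc(OC)c(OC)c(OC)c3)C2=O)cc(OC)c1OC` departs from compound 1 at one place: (2-fluorophenyl)carbonyl in place of hydrogen on an amine nitrogen in a ring. For the measured compounds named here, no measured pair shows this kind of change, so the expectation is tentative. A moderate move toward a stronger inhibitor, beyond the scatter, is expected, an estimated 3.3-fold lower number from compound 1 to compound 3 (0.52 log units; beyond the scatter). For compound 3 the estimated value in this assay is 1200 nM, with an expected range of 300 nM to 4500 nM.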

Compound 3, half-maximal inhibitory concentration: 1400 nM
The estimate for compound 3 lay 1.2-fold (0.07 log units) below the measured number; the range from low to high includes it.
By their numbers in this assay, from the lowest: compound 3; then compounds 1 and 2 (each within the scatter of the next).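

Compound 1 and compound 2 differ in more than one place, so they said nothing about this amine nitrogen in a ring on its own. In this assay, placing (2-fluorophenyl)carbonyl there instead of hydrogen gives a 2.9-fold lower number from compound 1 to compound 3 (0.46 log units; beyond the scatter) and shows that this position accepts a large group with a modest gain. No measurement shown here accounts for this step. The compounds shown leave open whether the gain depends on the fluorine, the aromatic ring or the carbonyl. Plain benzoyl, acetyl or benzyl on the same nitrogen would separate these parts.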